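From cyclohexylamino to dimethylamino on the sulfonyl sulfur

The source may hold more compounds than are shown below. What is called first, only, known or untested is meant among the compounds shown, and "the series" means these compounds.

- compound 1 `COC(=O)NC(=O)c1ccsc1NC(=O)c1ccc(S(=O)(=O)N2CCCCCC2)cc1` gives 9.13 ug/mL
- compound 2 `COC(=O)NC(=O)c1ccsc1NC(=O)c1ccc(S(=O)(=O)NC2CCCCC2)cc1` gives > 64 ug/mL (a limit, not a number)

Both values come from a toxicity assay on Vero cells (Chlorocebus sabaeus) for cytotoxicity, read by MTT assay (on this read-out lower numbers stand for stronger inhibition and higher numbers for weaker inhibition), and share the core of compound 1. Compound 2 stands at the limit of > 64 ug/mL in this assay, at which 1 of the 2 values shown sits, and so has a limit and no exact place in the series.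

The change to compound 3 `COC(=O)NC(=O)c1ccsc1NC(=O)c1ccc(S(=O)(=O)N(C)C)cc1` puts dimethylamino in place of cyclohexylamino on a sulfonyl sulfur. Going by the values given here, one measured step bears on this, since it also changes the amino group on that sulfur: an at least 7.0-fold higher number from compound 1 to compound 2 (0.84 log units; beyond the scatter) lies beyond the scatter. Taken in reverse, that step shows that replacing cyclohexylamino can bring a lower number, and compound 1 at 9.13 ug/mL marks how low this went. A single step sets no rule, and dimethylamino is not the group in compound 1, so a smaller drop is expected, and compound 3 could also stay at the limit. The expected move is an at least 2.1-fold lower number from compound 2 to compound 3 (0.32 log units; beyond the scatter) towards stronger inhibition, and it is only an estimate. In this assay compound 3 is estimated at 30 ug/mL (expected range 9 ug/mL to 64 ug/mL).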

Compound 3, half-maximal inhibitory concentration: 16.2 ug/mL
The estimate for compound 3 lay 1.9-fold (0.27 log units) above the measured number; the range from low to high includes it.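

In this assay, the step of an at least 3.9-fold lower number from compound 2 to compound 3 (0.59 log units; beyond the scatter) shows that this position on the sulfonyl sulfur can return to a measurable number with a group that has no ring, whereas the earlier pair showed a change only between two ring-bearing groups. The step of a 1.8-fold higher number from compound 1 to compound 3 (0.25 log units; within the scatter) stays within the scatter, so dimethylamino and azepan-1-yl cannot be told apart here, and a ring on this sulfur is not required for a number in this range among these compounds. The value of compound 2 is a limit and not a number, so its steps give only a minimum size: the limit of > 64 ug/mL in this assay, at which 1 of the 3 values shown sits.

The change from compound 2 to compound 3 removes the six-membered ring and the hydrogen-bond donor counted for cyclohexylamino together, so the compounds shown cannot say which of the two goes with the move in number. Methylamino would keep the amino hydrogen without the ring, and N-methylcyclohexylamino would keep the ring without that hydrogen, so these two groups would separate the two features.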